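The source may report more compounds than this note shows. Statements on the series, on what has been measured and on what is new or still open speak of the compounds shown alone.

Compound 1 `CCCc1nc(CC)c(C(=O)OCCCN2C(=O)c3ccccc3C2=O)n1Cc1ccc(-c2ccccc2S(=O)(=O)NC(=O)OCCC(C)C)cc1F` and compound 2 `CCCc1nc(CC)c(C(=O)OCCN2C(=O)c3ccccc3C2=O)n1Cc1ccc(-c2ccccc2S(=O)(=O)NC(=O)OCCC(C)C)cc1F` share a core and differ only in the length of the chain that carries the ring-bearing end group. In an assay on isolated protein for binding affinity to Type-2 angiotensin II receptor (Homo sapiens) (on this read-out lower numbers stand for stronger inhibition and higher numbers for weaker inhibition), compound 1 gives 3 nM, while compound 2 gives 7 nM. For the measured compounds named here, the one step so far, a 2.3-fold higher number from compound 1 to compound 2 (0.37 log units; beyond the scatter), shows that shortening that chain by one carbon weakened binding modestly, and compound 2 therefore stands with the highest number of the two, compound 1 being its only neighbour.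

Compound 3 `CCCc1nc(CC)c(C(=O)OCCCCOc2ccccc2)n1Cc1ccc(-c2ccccc2S(=O)(=O)NC(=O)OCCC(C)C)cc1F` keeps the chain length of compound 2 but exchanges the end group: a group of 9 heavy atoms (8 carbon, 1 oxygen; one six-membered aromatic ring of carbon only) in place of a group of 11 heavy atoms (8 carbon, 1 nitrogen, 2 oxygen; one five-membered non-aromatic ring with 1 hetero atom, one six-membered aromatic ring of carbon only), on a saturated chain carbon, two bonds along the chain from an oxygen next to a carbonyl group. Going by the values given here, no measured step bears directly on this exchange; the only step available concerns chain length, not the group at its end, and its size offers no guide to the direction here. The end group of compound 2 was tolerated well, and the replacement keeps an aromatic ring at a comparable distance from the ester, so compound 3 is expected to bind at a similar level, with the step of a 1.4-fold higher number from compound 2 to compound 3 (0.15 log units; within the scatter) estimated to stay close to the scatter. In this assay compound 3 is estimated at 10 nM, most likely between 3 nM and 35 nM.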

Compound 3, half-maximal inhibitory concentration: 2 nM
Estimate against measurement, compound 3: 5.0-fold (0.70 log units) above, and the stated range ends above it.
By their numbers in this assay, from the lowest: compounds 3 and 1 (each within the scatter of the next); then compound 2.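

In this assay, putting 2-phenoxyethyl on the saturated chain carbon, two bonds along the chain from an oxygen next to a carbonyl group, gives a 3.5-fold lower number from compound 2 to compound 3 (0.54 log units; beyond the scatter), so this position does not depend on the five-membered non-aromatic ring or the two double bonds outside aromatic rings of the leaving group. The comparison across end groups gives a 1.5-fold lower number from compound 1 to compound 3 (0.18 log units; within the scatter), which lies within the scatter, so the smaller group containing a single six-membered aromatic ring and an ether oxygen reads level with the larger end group of compound 1. The result therefore adds a second end group type to the low-nanomolar readings, and nothing available explains why the exchange moved the number as it did.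

From the compounds shown here alone, all three compounds carry an aromatic ring at the end of the chain, so it remains open whether that ring is needed at all, a question that a plain ethyl ester, or an amine or a carboxylic acid at the chain end, would address. Also open, going by these compounds, is whether the phenoxy end responds to chain length as the larger end group did, as a longer chain such as 3-phenoxypropyl would show.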